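Aryl substitution and hepatocyte clearance in the isoxazoline series

The source may hold more compounds than are shown below. What is called first, only, known or untested is meant among the compounds shown, and "the series" means these compounds.

Measured compounds:
compound 1 `COc1nc(C2=NOCC(c3ccc(Cl)cc3)N2)ccc1-n1cnc(C)c1`: 2 mL/min/kg
compound 2 `COc1nc(C2=NOCC(c3ccc(C)cc3)N2)ccc1-n1cnc(C)c1`: 135 mL/min/kg
compound 3 `COc1nc(C2=NOCC(c3cccc(C4CC4)c3)N2)ccc1-n1cnc(C)c1`: 29 mL/min/kg

In an ADME assay on cells (Hepatocyte, Homo sapiens) for pharmacokinetics (a higher number here means faster removal of the compound, a lower number slower removal), compound 2 stands highest of the three measured compounds; the step of a 68-fold higher number from compound 1 to compound 2 (1.83 log units; beyond the scatter) and the step of a 4.7-fold lower number from compound 2 to compound 3 (0.67 log units; beyond the scatter) both set it apart from the others, beyond the scatter. Compound 4 `COc1nc(C2=NOCC(c3ccc(C)c(Cl)c3)N2)ccc1-n1cnc(C)c1` is not yet measured. It differs from compound 2 by chloro in place of hydrogen on an aromatic carbon; cut one bond further out, this reads 4-methylphenyl to 3-chloro-4-methylphenyl. The step that bears on this change is a 68-fold higher number from compound 1 to compound 2 (1.83 log units; beyond the scatter), in which chloro gave way to methyl on this ring and the number rose sharply. Compound 4 keeps the methyl and regains a chloro, so a drop from compound 2 in this assay is expected, estimated as a 5.4-fold lower number from compound 2 to compound 4 (0.73 log units; beyond the scatter). For compound 4 the expected value is 25 mL/min/kg, within 6 mL/min/kg to 80 mL/min/kg.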

Compound 4, clearance: 422 mL/min/kg
For compound 4 the middle estimate is 17-fold (1.23 log units) below the measured one; measured number above the stated range.
By their numbers in this assay, from the lowest: compound 1; then compound 3; then compound 2; then compound 4.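

In this assay, chloro added to the 4-methylphenyl ring gives a 3.1-fold higher number from compound 2 to compound 4 (0.49 log units; beyond the scatter) and so does not go with slower removal on this ring. The 3-chloro-4-methylphenyl ring also gives a 210-fold higher number from compound 1 to compound 4 (2.32 log units; beyond the scatter) and a 15-fold higher number from compound 3 to compound 4 (1.16 log units; beyond the scatter) in the same direction, which leaves 4-chlorophenyl as the only chloro-bearing ring shown with a low number. Nothing available explains this rise.

On these data alone, whether the rise belongs to chloro itself or to chloro paired with the methyl stays open. A 3-chlorophenyl ring, or fluoro or methoxy on the same carbon, would separate these readings.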